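Methyl on the side chain of a bicyclic sulfonyl guanidine core

A few compounds are considered here, and "the series" means these few. Any claim that something is new, unique, unknown or untested is made for them only; others in the source may bear on it.

Measured so far:
compound 1 `CC(C)C(C)NC1=NS(=O)(=O)c2cccnc2N1`, > 300 uM
compound 2 `CC(NC1=NS(=O)(=O)c2cccnc2N1)C(C)(C)C`, > 300 uM
compound 3 `O=S1(=O)N=C(NCc2ccccc2)Nc2ncccc21`, > 300 uM

In a functional assay (ileum) for inhibition, with Cavia porcellus as the target (on this read-out lower numbers stand for an effect already at smaller amounts and higher numbers for an effect only at larger amounts of compound), compound 1 reaches only the limit of the assay, > 300 uM, not a number. Compound 2, which carries methyl in place of hydrogen on a saturated chain carbon bound to three saturated chain carbons, sits at the same limit, > 300 uM. The step that the two limits leave unreadable from compound 1 to compound 2 therefore cannot be read, because the limit of > 300 uM in this assay, at which 3 of the 3 values shown sit, hides it. Compound 3 also ends at a limit, > 300 uM. The difference between the cores of compound 1 and compound 3 is not broken down here.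

Compound 4 `C[C@H](NC1=NS(=O)(=O)c2cccnc2N1)c1ccccc1` is not yet measured in this assay. Its change from compound 3 is methyl in place of hydrogen on a saturated chain carbon bound to an amine nitrogen and an aromatic carbon, the same kind of change as from compound 1 to compound 2, but at a different place: there the carbon was bound to three saturated chain carbons, here it is bound to an amine nitrogen and an aromatic carbon. Among the measured compounds shown here, since every value so far sits at the limit of > 300 uM in this assay, at which 3 of the 3 values shown sit, compound 4 is expected to show a number no higher from compound 3 to compound 4 (the limit leaves the size open) and to end near the limit again, estimated at 300 uM, between 100 uM and 1000 uM.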

Compound 4, concentration for half-maximal effect: > 300 uM
Compound 4 gave a limit, no number; the forecaster's own chance of this, stated with the estimate: 80%; the middle value sits exactly at the limit.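

Compound 4 gives [ > 300 uM ], a limit and not a number. The methyl step between compound 3 and compound 4 therefore cannot be read, because every value ends at the same limit: the limit of > 300 uM in this assay, at which 4 of the 4 values shown sit.

The compounds shown leave open whether any side chain on this core gives a readable number in this assay.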